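This account rests on a few compounds, and the source may have more. Where it says the series, first, only, none or still open, it means among the compounds named here.

Going by the values given here, in a physicochemical assay for lipophilicity, at pH 7.4 (on this read-out higher numbers stand for higher lipophilicity and lower numbers for lower lipophilicity), compound 1 `CCc1ccc(N(CC(C)C)S(=O)(=O)c2ccc3c(c2)C(O)CC(C2CCNCC2)O3)cc1` gives 1.04, the lower of the two numbers measured so far. In this assay, compound 2 `CCc1ccc(N(CC(C)C)S(=O)(=O)c2ccc(OCC3CCOCC3)c(CN)c2)cc1` gives 3.25, a gap well beyond the usual scatter of repeated measurements. Compound 3 `CCc1ccc(N(CC(C)C)S(=O)(=O)c2ccc3c(c2)C(O)CC(C2CCN(C)CC2)O3)cc1` keeps the whole of compound 1 except for one site, where a small substitution is made: methyl in place of hydrogen on an amine nitrogen in a ring, (methyl in place of hydrogen on an amine nitrogen in a ring). The same difference can be read as piperidin-4-yl becoming 1-methylpiperidin-4-yl.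

Among the compounds with values here, no pair of measured compounds shows this substitution, so the data offer no direct precedent, and the expectation rests on the structural change alone. Adding a single carbon is a small edit, so a modest upward move is expected from the starting point of compound 1 at 1.04. The estimated step is a number 0.46 log units higher from compound 1 to compound 3 (beyond the scatter), somewhat beyond the scatter, although a result within the scatter would be no great surprise. In this assay, compound 3 is estimated at 1.5, with an expected range from 1.1 to 2.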

Compound 3, distribution coefficient: 2.67
The estimate for compound 3 lay 1.17 log units below the measured number; the whole stated range lies below it.
By their numbers in this assay, from the lowest: compound 1; then compound 3; then compound 2.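

In this assay, putting methyl in place of hydrogen on the amine nitrogen of the six-membered ring gives a number 1.63 log units higher from compound 1 to compound 3 (beyond the scatter) and this counts as a large step. The edit adds only one heavy atom, a single carbon, with no new ring, no hydrogen-bond donor or acceptor and no net charge, so this one pair shows that a very small change at this site can shift the read-out strongly. Nothing available explains why the step is so large.

The compounds shown do not reveal whether an ethyl group or a longer chain on this same nitrogen would push the number further in the same direction, stop the rise or reverse it, nor how an acetyl group, which places a carbonyl on that nitrogen, would compare. On these data alone, since this is a single pair of compounds, it also remains open whether the same swap of hydrogen for methyl would give a step of similar size on a different core.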